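A swap on the carbonyl carbon of compound 2

A few compounds are considered here, and "the series" means these few. Any claim that something is new, unique, unknown or untested is made for them only; others in the source may bear on it.

Measured in an ADME assay on microsomes from liver (Mus musculus) for metabolic stability, read by LC-MS, with a stated time of 30 min, tested at 1 uM; on this read-out higher numbers stand for a more stable compound and lower numbers for a less stable compound:
- Compound 1 `O=C(NCc1ccc(S(=O)(=O)c2ccccc2)cc1)c1ccc2nccn2c1` gives 18%
- Compound 2 `O=C(NCc1ccc(S(=O)(=O)N2CCCCC2)cc1)c1cc2cnccc2s1` gives "below limit of detection" (no number reported)

The account follows the step from compound 2 to an unmeasured neighbour. Compound 2 stands at "below limit of detection" (no number reported), and no single number exists for it. Compound 3 `O=C(NCc1ccc(S(=O)(=O)N2CCCCC2)cc1)c1ccn2cncc2c1` differs from compound 2 in one place, on a carbonyl carbon: a group of 9 heavy atoms (7 carbon, 2 nitrogen; one five-membered aromatic ring with 2 hetero atoms, one six-membered aromatic ring with 1 hetero atom) in place of a group of 9 heavy atoms (7 carbon, 1 nitrogen, 1 sulfur; one five-membered aromatic ring with 1 hetero atom, one six-membered aromatic ring with 1 hetero atom), on a carbonyl carbon. The group that leaves holds sulfur, and the one that enters does not.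

Among the compounds with values here, no measured pair in this set differs in one place only, so the data show no precedent for this change. Without a number for compound 2, the size of the step cannot be worked out from the data. At most a small rise in this assay is expected, and possibly none beyond the scatter. Within the data shown here, the only number available is that of compound 1 at 18%, so the expectation stays low on the scale. A further result without a number would be no surprise. For compound 3 the estimated value is 10%, with an expected range from 1% to 28%.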

Compound 3, percent of the compound remaining: 1%
For compound 3 the middle estimate is 9 percentage points above the measured one, and the stated range covers the measured number.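

In this assay, within the data shown here, compound 3 gives 1%, but compound 2 has no single number, so no step from compound 2 to compound 3 can be read. The compounds shown leave open how far the swap on the carbonyl carbon shifts the percent of compound remaining. Nothing shown offers an explanation for the result.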